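From compound 3 to compound 4: one methyl fewer

The source may report more compounds than this note shows. Statements on the series, on what has been measured and on what is new or still open speak of the compounds shown alone.

Compound 1 `COC(=O)CCCNC(=O)c1cc(C)cc2c1NC(C)(C)C=C2C` reads > 30000 nM (a limit).
Compound 2 `COC(=O)/C=C/CNC(=O)c1cccc2c1NCCC2` reads > 30000 nM (a limit).
Compound 3 `COC(=O)/C=C/CNC(=O)c1cc(C)cc2c1NC(C)(C)C=C2C` reads > 30000 nM (a limit).

In an ADME assay on HeLa cells (Homo sapiens) for cytotoxicity (a higher number here means that more compound is tolerated, a lower number that less compound is tolerated), compound 3 stands at > 30000 nM, which is a limit and not a number. Going by the values given here, it has company there, as the series so far shows (the limit of > 30000 nM in this assay, at which 3 of the 3 values shown sit).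

The next compound is compound 4 `COC(=O)/C=C/CNC(=O)c1cccc2c1NC(C)(C)C=C2C`, which carries hydrogen in place of methyl on an aromatic carbon. Only one measured step connects two of these compounds, a step that the two limits leave unreadable from compound 1 to compound 3, and it concerns the chain, not this aromatic carbon. It therefore gives no size to carry over. Compound 2 , which also lacks this methyl though its core differs, reads > 30000 nM, again a limit.

On this evidence, no step beyond the scatter is expected in this assay, in either direction. The estimated change is a number no higher from compound 3 to compound 4 (the limit leaves the size open). For compound 4 the expected value is 30000 nM, with an estimated range from 15000 nM to 60000 nM.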

Compound 4, half-maximal cytotoxic concentration: > 30000 nM
Compound 4: a limit, no number; the forecaster's own chance of this, stated with the estimate: 90%; the middle value sits exactly at the limit.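

In this assay compound 4 gives > 30000 nM which is a limit and not a number. Going by these compounds alone, compound 3 also reads as a limit, so no step between the two can be read. The compounds shown leave open at what concentration any of them becomes cytotoxic, and whether losing the methyl changes that.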